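This account rests on a few compounds, and the source may have more. Where it says the series, first, only, none or still open, it means among the compounds named here.

Working notes on the series. All compounds share the core of compound 1 `CC(C)CN(CC(C)C)S(=O)(=O)c1ccc(NC(=O)C(C)(O)C(F)(F)F)cc1`. In an assay on a protein complex (Cavia porcellus) with sulfonylurea receptors; K-ATP channels (Homo sapiens) as the target (a lower number here means a stronger inhibitor, a higher number a weaker inhibitor), compound 1 gives > 30000 nM, which is a limit of the assay and not a number. Compound 2 `CC(O)(C(=O)Nc1ccc(/C(=N\O)c2ccccc2)cc1)C(F)(F)F` gives > 30000 nM in this assay, likewise a limit. Compound 3 `CC(O)(C(=O)Nc1ccc([C@@H](O)c2ccccc2)cc1)C(F)(F)F` gives > 30000 nM in this assay, again a limit. Within the data shown here, no step between measured compounds can be read from these data, since (the limit of > 30000 nM in this assay, at which 3 of the 3 values shown sit). Compound 4 `CC(O)(C(=O)Nc1ccc(S(=O)(=O)N2CCCCC2)cc1)C(F)(F)F` has not yet been measured in this assay; it differs from compound 1 by piperidin-1-yl in place of diisobutylamino on a sulfonyl sulfur. With every measured value sitting at the limit, nothing in the series shows that a change on the sulfonyl sulfur brings the read-out into the measurable range, so the expected step is a number no higher from compound 1 to compound 4 (the limit leaves the size open), none beyond the scatter. Compound 4 is therefore expected to give about 30000 nM in this assay, with a range from 10000 nM to 100000 nM, and most likely to be reported once more only as a limit.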

Compound 4, half-maximal inhibitory concentration: 9250 nM
Estimate against measurement, compound 4: 3.2-fold (0.51 log units) above; the measured number lies below the stated range.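

In this assay, among these compounds, the sulfonyl sulfur is the first place where a change moves the read-out off the limit: piperidin-1-yl in place of diisobutylamino gives an at least 3.2-fold lower number from compound 1 to compound 4 (0.51 log units; beyond the scatter). Among the compounds shown here, compound 4 therefore supplies the only actual number so far, and the change that gives it swaps an open diisobutylamino group for a six-membered non-aromatic ring with fewer heavy atoms. Compound 1 gives > 30000 nM, which is a limit and not a number, so the step has a lower bound but no measured size: the limit of > 30000 nM in this assay, at which 3 of the 4 values shown sit.

This single pair cannot separate the presence of the ring from the smaller heavy-atom count. Going by these compounds, how a diethylamino group or a morpholine ring on the sulfonyl sulfur would read in this assay remains open.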